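The source may report more compounds than this note shows. Statements on the series, on what has been measured and on what is new or still open speak of the compounds shown alone.

Of the compounds shown here, three of one series have been measured in an ADME assay on LLC-MK2 cells (Macaca mulatta) for cytotoxicity, read by spectrophotometry and crystal violet staining, with a stated time of 4 days; on this read-out higher numbers stand for lower toxicity in this test and lower numbers for higher toxicity in this test. Compound 1 `CC(C)n1ncc2c(C(=O)N3CCc4cccnc43)cc(-c3cccs3)nc21` gives 50000 nM, compound 2 `CC(C)n1ncc2c(C(=O)Nc3cncnc3)cc(-c3cccs3)nc21` gives 20000 nM, and compound 3 `CC(C)n1ncc2c(C(=O)Nc3cc(S(N)(=O)=O)ccc3F)cc(-c3cccs3)nc21` gives 25000 nM. For the measured compounds named here, compound 2 stands at the lowest of the three numbers; its value and that of compound 3 lie within the scatter of each other, while the step of a 2.5-fold lower number from compound 1 to compound 2 (0.40 log units; beyond the scatter) is beyond the scatter and is the only change that clearly moves this read-out.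

Compound 4 `CC(C)n1ncc2c(C(=O)Nc3ccncn3)cc(-c3cccs3)nc21` has the same atoms as compound 2, joined differently: pyrimidin-4-yl in place of pyrimidin-5-yl on an amide-type nitrogen. Going by the values given here, no measured step bears directly on this change; the one step that exists, a 2.5-fold lower number from compound 1 to compound 2 (0.40 log units; beyond the scatter), replaces the whole group on the carbonyl carbon, whereas here the pyrimidin-5-yl group and the pyrimidin-4-yl group are alike in everything counted. With no evidence for a shift in either direction, the expected step of no change at the digits printed from compound 2 to compound 4 (within the scatter) is nothing beyond the scatter. Compound 4 is therefore estimated to give about 20000 nM in this assay, with a likely range from 8000 nM to 50000 nM.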

Compound 4, half-maximal cytotoxic concentration: 50000 nM
Compound 4: the middle estimate sits 2.5-fold (0.40 log units) below what was measured; the measured number falls inside the stated range.
By their numbers in this assay, from the lowest: compounds 2, 3, 1 and 4 (each within the scatter of the next, the first and the last beyond it).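

In this assay, the amide-type nitrogen proves sensitive to how the same atoms are joined: pyrimidin-4-yl in place of pyrimidin-5-yl gives a 2.5-fold higher number from compound 2 to compound 4 (0.40 log units; beyond the scatter), although the two groups are alike in everything counted. Replacing the group on the carbonyl carbon gives no change at the digits printed from compound 1 to compound 4 (within the scatter), so swapping this group need not move the read-out, and the outcome depends on which pyrimidinyl group enters. Nothing available explains why the two pyrimidinyl groups differ in this test.

The compounds shown leave open whether a pyridin-3-yl or pyridin-4-yl group on the amide-type nitrogen would read like compound 2 or like compound 4. They also leave open what a methyl or amino group on the pyrimidin-4-yl ring would do to the read-out.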